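The source may report more compounds than this note shows. Statements on the series, on what has been measured and on what is new or still open speak of the compounds shown alone.

Compound 1 `Cc1ccc(C(=O)Nc2cc(-c3cnn(C)c3)cc(C(F)(F)F)c2)cc1Nc1cc(-c2cccnc2)ccn1` was tested in a toxicity assay on SH-SY5Y cells (Homo sapiens) for cytotoxicity, read by MTT assay, with a stated time of 48 h; on this read-out higher numbers stand for weaker inhibition and lower numbers for stronger inhibition. In this assay compound 1 gives > 80000 nM, which is a limit of the assay rather than a measured number. Compound 2 `Cc1cn(-c2cc(NC(=O)c3ccc(C)c(Nc4cc(-c5cccnc5)ccn4)c3)cc(C(F)(F)F)c2)cn1` differs from compound 1 in a single group; in this assay compound 2 gives > 80000 nM, again a limit. The step that the two limits leave unreadable from compound 1 to compound 2 therefore cannot be read because of the limit of > 80000 nM in this assay, at which 2 of the 2 values shown sit. Compound 3 `Cc1ccc(C(=O)Nc2cc(-c3cnn(C)c3)cc(C(F)(F)F)c2)cc1Nc1cc(-c2cncnc2)ccn1` has not yet been measured; it differs from compound 1 by pyrimidin-5-yl in place of pyridin-3-yl on an aromatic carbon. Within the data shown here, no measured step bears directly on this change, and the one measured step available is unreadable. Compound 1 sits at the limit, so compound 3 is expected to sit there as well, with no step beyond the scatter readable; the expected step is a number no higher from compound 1 to compound 3 (the limit leaves the size open). In this assay compound 3 is estimated to give 80000 nM, between 40000 nM and 160000 nM.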

Compound 3, half-maximal inhibitory concentration: > 80000 nM
Compound 3 was reported as a limit (the forecaster's own chance of this, stated with the estimate: 75%); the middle value lies on the limit itself.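

In this assay compound 1 and compound 3 both sit at a limit, not at a measured number, so no step can be read between them: the limit of > 80000 nM in this assay, at which 3 of the 3 values shown sit. As far as these compounds go, whether compound 1, compound 2 and compound 3 differ at all in this assay stays open.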